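Ethyl to isopropyl on the ring amine nitrogen

The source may report more compounds than this note shows. Statements on the series, on what has been measured and on what is new or still open speak of the compounds shown alone.

Two compounds of the shared core have numbers in an assay on HeLa cells for displacement of a labelled ligand from 5-hydroxytryptamine receptor 6 (Homo sapiens); on this read-out higher numbers stand for weaker inhibition and lower numbers for stronger inhibition. Compound 1 `O=S(=O)(c1cccc(F)c1)c1cn(C2CCCNC2)c2ncccc12` gives 2.4 nM. Within the data shown here, compound 2 `CCN1CCCC(n2cc(S(=O)(=O)c3cccc(F)c3)c3cccnc32)C1` gives 4.4 nM, the higher of the two numbers, with compound 1 its nearest neighbour; the only step between them, a 1.8-fold higher number from compound 1 to compound 2 (0.26 log units; within the scatter), lies within the scatter, so the two cannot be ordered.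

Compound 3 `CC(C)N1CCCC(n2cc(S(=O)(=O)c3cccc(F)c3)c3cccnc32)C1` has not yet been measured in this assay. It differs from compound 2 by methyl in place of hydrogen on a saturated chain carbon bound to an amine nitrogen in a ring and a saturated chain carbon. Among the measured compounds shown here, the one measured step that bears on this change is the earlier growth of the chain on the same amine nitrogen in a ring, a 1.8-fold higher number from compound 1 to compound 2 (0.26 log units; within the scatter), which stayed within the scatter. Adding a further methyl on that chain is therefore expected to give at most a small shift in this assay, if any beyond the scatter. Given that the earlier step of a 1.8-fold higher number from compound 1 to compound 2 (0.26 log units; within the scatter) pointed toward a higher number, the step expected for compound 3 is a 1.4-fold higher number from compound 2 to compound 3 (0.13 log units; within the scatter). Compound 3 is estimated at 6 nM, with a range from 2.5 nM to 15 nM.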

Compound 3, inhibition constant: 3.4 nM
The estimate for compound 3 lay 1.8-fold (0.25 log units) above the measured number; measured number inside the range.
By their numbers in this assay, from the lowest: compounds 1, 3 and 2 (each within the scatter of the next).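

In this assay, among these compounds, the move from ethyl to isopropyl gives a 1.3-fold lower number from compound 2 to compound 3 (0.11 log units; within the scatter), so a methyl on the saturated chain carbon bound to the amine nitrogen in a ring, which turns the straight ethyl into a branched group, gives no step that can be told from the scatter. Set against the hydrogen of the parent amine, isopropyl gives a 1.4-fold higher number from compound 1 to compound 3 (0.15 log units; within the scatter), which completes the set: hydrogen, ethyl and isopropyl on this nitrogen all lie within the scatter of one another, so among compounds 1, 2 and 3 the read-out does not separate these groups, and branching at this carbon adds no separation of its own. No accompanying data bear on the reason for this flat stretch of the series.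

All three steps at this nitrogen stay within the scatter, so the size of group at which the number would move beyond the scatter remains undefined. A longer chain such as n-butyl, a benzyl group or a chain ending in a carboxylic acid on the same nitrogen would test whether this position stays as flat beyond isopropyl.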